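Aryl ketone variation on the carbonyl carbon

This account rests on a few compounds, and the source may have more. Where it says the series, first, only, none or still open, it means among the compounds named here.

Measured compounds:
compound 1 `COc1ccc(-c2cc3ccccc3nc2/C=C/C(=O)c2ccccc2)cc1`: 700 nM
compound 2 `COc1ccc(-c2cc3ccccc3nc2/C=C/C(=O)c2ccc([N+](=O)[O-])cc2)cc1`: 590 nM
compound 3 `COc1ccc(-c2cc3ccccc3nc2/C=C/C(=O)c2ccccn2)cc1`: 370 nM

All three were read in a functional assay on SK-BR-3 cells (Homo sapiens) for antiproliferative activity, read by XTT assay, with a stated time of 72 h; a higher number here means a weaker inhibitor, a lower number a stronger inhibitor. Compound 3 sits at the low end of the three values, but the steps of a 1.9-fold lower number from compound 1 to compound 3 (0.28 log units; within the scatter) and a 1.6-fold lower number from compound 2 to compound 3 (0.20 log units; within the scatter) are both within the scatter, so no ordering among compounds 1, 2 and 3 is claimed. The step of a 1.2-fold lower number from compound 1 to compound 2 (0.07 log units; within the scatter) is likewise within the scatter.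

Compound 4 `COc1ccc(-c2cc3ccccc3nc2/C=C/C(=O)c2ccsc2)cc1` is not yet measured. It differs from compound 3 by thiophen-3-yl in place of pyridin-2-yl on a carbonyl carbon. For the measured compounds named here, the steps that bear on this are the two exchanges on the same carbonyl carbon, a 1.9-fold lower number from compound 1 to compound 3 (0.28 log units; within the scatter) and a 1.6-fold lower number from compound 2 to compound 3 (0.20 log units; within the scatter), neither of which moved the number beyond the scatter. The expected step of a 1.4-fold higher number from compound 3 to compound 4 (0.13 log units; within the scatter) is therefore small, if anything a slight rise back toward the values of compounds 1 and 2, and not beyond the scatter. For compound 4 the estimate in this assay is 500 nM, with a range from 200 nM to 1400 nM.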

Compound 4, half-maximal inhibitory concentration: 660 nM
Compound 4: middle estimate off by 1.3-fold (0.12 log units), on the low side; low and high end bracket the measured number.
By their numbers in this assay, from the lowest: compounds 3, 2, 4 and 1 (each within the scatter of the next).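

Thiophen-3-yl brings a five-membered aromatic ring with a sulfur atom onto the carbonyl carbon, where the earlier compounds carried only six-membered aromatic rings. In this assay, this change of ring size and hetero atom gives no step beyond the scatter: a 1.8-fold higher number from compound 3 to compound 4 (0.25 log units; within the scatter), a 1.1-fold higher number from compound 2 to compound 4 (0.05 log units; within the scatter), and a 1.1-fold lower number from compound 1 to compound 4 (0.03 log units; within the scatter). Nothing further is available to explain these numbers.

Among these four compounds, every group on the carbonyl carbon is an aromatic ring, so it remains open whether a non-aromatic group there, such as a cyclohexyl ring, a longer alkyl chain or a chain ending in an amine, would move the number beyond the scatter. The same question stands for a phenyl ring bearing a carboxylic acid.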